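Compound 4 against the cytotoxicity limit of compound 3

The source may hold more compounds than are shown below. What is called first, only, known or untested is meant among the compounds shown, and "the series" means these compounds.

Three compounds share one core. Compound 1 `COc1ccccc1N1CCN(CC(O)Cn2c([N+](=O)[O-])cnc2C)CC1` gives 4390000 nM in a toxicity assay on HeLa cells (Homo sapiens) for cytotoxicity, read by MTT assay, with a stated time of 24 h; a lower number here means a stronger inhibitor, a higher number a weaker inhibitor. Compound 2 `Cc1ncc([N+](=O)[O-])n1CC(O)CN1CCN(c2ccccn2)CC1` gives 1830000 nM in this assay, a step of a 2.4-fold lower number from compound 1 to compound 2 (0.38 log units; beyond the scatter). For compound 3 `Cc1ncc([N+](=O)[O-])n1CC(O)CN1CCN(c2ccccc2F)CC1` the reading in this assay is only a limit, > 5000000 nM, namely (the limit of > 5000000 nM in this assay, at which 1 of the 3 values shown sits). Compound 3 therefore stands at the weak end of the three: the step of an at least 2.7-fold higher number from compound 2 to compound 3 (0.43 log units; beyond the scatter) is beyond the scatter, while the step of an at least 1.1-fold higher number from compound 1 to compound 3 (0.05 log units; that floor lies within the scatter) lies within it.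

Compound 4 `Cc1ncc([N+](=O)[O-])n1CC(O)CN1CCN(c2cccc(Cl)c2)CC1` differs from compound 3 by 3-chlorophenyl in place of 2-fluorophenyl on an amine nitrogen in a ring. Going by the values given here, no measured step replaces the fluorine with chlorine; the steps that bear on this position, an at least 1.1-fold higher number from compound 1 to compound 3 (0.05 log units; that floor lies within the scatter) and an at least 2.7-fold higher number from compound 2 to compound 3 (0.43 log units; beyond the scatter), show that changing the aryl group on the ring nitrogen moved the number modestly and in no case away from weak inhibition. One therefore expects for compound 4 a step of an at least 1.2-fold lower number from compound 3 to compound 4 (0.09 log units; that floor lies within the scatter) that stays close to the scatter, possibly a little lower than the limit of compound 3. Compound 4 is estimated at 4000000 nM, between 1500000 nM and 10000000 nM.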

Compound 4, half-maximal inhibitory concentration: 1440000 nM
The estimate for compound 4 lay 2.8-fold (0.44 log units) above the measured number; the measured number lies below the stated range.
By their numbers in this assay, from the lowest: compounds 4 and 2 (each within the scatter of the next); then compound 1. At a limit, above all of these: compound 3.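

In this assay, the 3-chlorophenyl group on the amine nitrogen in a ring gives a 3.0-fold lower number from compound 1 to compound 4 (0.48 log units; beyond the scatter), so a phenyl ring of carbon only can lower the number beyond the scatter, which neither the 2-methoxyphenyl nor the 2-fluorophenyl group had shown. The pyridin-2-yl group, until now the only one at this low level, is not needed to reach it: a 1.3-fold lower number from compound 2 to compound 4 (0.10 log units; within the scatter), and compound 2 and compound 4 cannot be told apart. The reading of compound 3 is a limit, so an at least 3.4-fold lower number from compound 3 to compound 4 (0.54 log units; beyond the scatter) gives only a floor: the limit of > 5000000 nM in this assay, at which 1 of the 4 values shown sits.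

The 2-fluorophenyl and 3-chlorophenyl groups differ in both the halogen and its place on the ring, and the compounds shown cannot separate the two. Going by these compounds, how a phenyl ring bearing an amine or a carboxylic acid would read in this assay also stays open.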